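The source may hold more compounds than are shown below. What is called first, only, known or untested is meant among the compounds shown, and "the series" means these compounds.

Measured compounds:
- compound 2 `Cc1nn2cc(-c3cc4ccccc4o3)nc2s1`: 37 nM
- compound 1 `c1ccc(Sc2nn3cc(-c4cc5ccccc5o4)nc3s2)cc1`: 1900 nM

Both compounds share the same core and were tested in a functional assay on HEK293 cells for antagonist activity at proteinase-activated receptor 4 (Homo sapiens), read by FLIPR and calcium flux, with a stated time of 30 min; a higher number here means a weaker inhibitor, a lower number a stronger inhibitor. Compound 2 gives 37 nM, the lower of the two numbers, and compound 1 gives 1900 nM. For the measured compounds named here, the only step recorded between them, a 51-fold lower number from compound 1 to compound 2 (1.71 log units; beyond the scatter), shows that swapping one group on that aromatic carbon can move the number a long way.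

Compound 3 `CCOc1nn2cc(-c3cc4ccccc4o3)nc2s1` has not yet been tested. It differs from compound 2 by ethoxy in place of methyl on an aromatic carbon. Going by the values given here, the group entering is counted at more heavy atoms than methyl but far fewer than phenylsulfanyl, so the one known step bears on it only loosely. A modest rise in the number, or no change beyond the scatter, seems the most likely outcome. Compound 3 is therefore estimated at 80 nM, within 20 nM to 400 nM, which would mean a step of a 2.2-fold higher number from compound 2 to compound 3 (0.33 log units; beyond the scatter).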

Compound 3, half-maximal inhibitory concentration: 67 nM
The estimate for compound 3 lay 1.2-fold (0.08 log units) above the measured number; measured number inside the range.
By their numbers in this assay, from the lowest: compounds 2 and 3 (each within the scatter of the next); then compound 1.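

Replacing methyl with ethoxy on this aromatic carbon gives a 1.8-fold higher number from compound 2 to compound 3 (0.26 log units; within the scatter), so adding the oxygen and the longer chain leaves the number indistinguishable from that of the methyl compound. The other new step, a 28-fold lower number from compound 1 to compound 3 (1.45 log units; beyond the scatter), shows that ethoxy, like methyl, stands far from phenylsulfanyl, so a group larger than methyl does not necessarily bring the large rise seen with compound 1. Nothing available explains why phenylsulfanyl differs so much from these two smaller groups.

The compounds shown leave open how far the chain can grow before the number rises, as a propoxy or butoxy group would test. They also leave open whether an amine on this carbon, or a phenyl ring attached directly without the sulfur, would behave like ethoxy or like phenylsulfanyl.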